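Substance-P Receptor Series: From the Ring Oxide to a Methoxypyridine

The source may report more compounds than this note shows. Statements on the series, on what has been measured and on what is new or still open speak of the compounds shown alone.

Measured compounds:
Compound 1, `C[C@@H](O[C@H]1CN2C(=O)C=C(c3ccccc3)CC2[C@@H]1c1ccc(F)cc1)c1cc(C(F)(F)F)cc(C(F)(F)F)c1`: 0.93 nM
Compound 2, `C[C@@H](O[C@H]1CN2C(=O)C=C(c3cc[n+]([O-])cc3)CC2[C@@H]1c1ccc(F)cc1)c1cc(C(F)(F)F)cc(C(F)(F)F)c1`: 0.1 nM

In an assay on CHO cells for displacement of a labelled ligand from Substance-P receptor (Homo sapiens) (a higher number here means a weaker inhibitor, a lower number a stronger inhibitor), compound 2 gives the lowest of the two numbers shown, and the nearest value, that of compound 1, is a 9.3-fold lower number from compound 1 to compound 2 (0.97 log units; beyond the scatter).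

Compound 3, `COc1cc(C2=CC(=O)N3C[C@H](O[C@H](C)c4cc(C(F)(F)F)cc(C(F)(F)F)c4)[C@@H](c4ccc(F)cc4)C3C2)ccn1`, has not yet been measured in this assay. Its change from compound 2 is a group of 8 heavy atoms (6 carbon, 1 nitrogen, 1 oxygen; one six-membered aromatic ring with 1 hetero atom) in place of a group of 7 heavy atoms (5 carbon, 1 nitrogen, 1 oxygen; one six-membered aromatic ring with 1 hetero atom), on a double-bonded ring carbon.

For the measured compounds named here, the only measured step that bears on this place is the one from compound 1 to compound 2, where a six-membered aromatic ring of carbon only was replaced by a ring with one hetero atom and the number fell, a 9.3-fold lower number from compound 1 to compound 2 (0.97 log units; beyond the scatter). Going by the values given here, no measured pair shows what the 2-methoxypyridin-4-yl group itself does at this position. Since compound 3 keeps a six-membered aromatic ring with one hetero atom, its number is expected to stay close to that of compound 2, with a small step upward, a 3.0-fold higher number from compound 2 to compound 3 (0.48 log units; beyond the scatter), that may fall within the scatter. Compound 3 is therefore estimated at 0.3 nM, within 0.08 nM to 1.2 nM.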

Compound 3, half-maximal inhibitory concentration: 1.1 nM
The estimate for compound 3 lay 3.7-fold (0.56 log units) below the measured number; measured number inside the range.
By their numbers in this assay, from the lowest: compound 2; then compounds 1 and 3 (each within the scatter of the next).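

In this assay, the new result shows that a six-membered aromatic ring with one hetero atom does not by itself bring the low number at this double-bonded ring carbon: putting 2-methoxypyridin-4-yl in place of the ring oxide group gives an 11-fold higher number from compound 2 to compound 3 (1.04 log units; beyond the scatter). Set against phenyl, the same group gives a 1.2-fold higher number from compound 1 to compound 3 (0.07 log units; within the scatter), so at this position 2-methoxypyridin-4-yl and phenyl cannot be told apart, and among the three compounds only the ring oxide group of compound 2 stands out. Nothing available explains why the ring oxide group and 2-methoxypyridin-4-yl differ so widely in this assay.

The compounds shown leave open where a plain pyridin-4-yl group, carrying neither the methoxy group nor the ring oxide, would fall, so the part played by the ring nitrogen cannot be separated from that of the methoxy group or the ring oxide. They also leave open whether an ethoxy group or an amine in place of the methoxy group on the pyridine ring would move the number at all.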